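A chloro group added to compound 2

The compounds below may be only part of what the source reports. "The series", "measured", "known", "first", "only" and "open" are said of these compounds alone.

Compound 1 `Cc1ccc(C)c(NS(=O)(=O)c2cccc(CCCCCCNC(=O)/C=C/c3cccnc3)c2)c1` gives 7.48 nM
Compound 2 `O=C(/C=C/c1cccnc1)NCCCCCCc1cccc(S(=O)(=O)Nc2ccc(F)cc2)c1` gives 10.6 nM

In a functional assay on DU-145 cells (Homo sapiens) for inhibition, read by CCK-8 assay, with a stated time of 72 h (on this read-out lower numbers stand for stronger inhibition and higher numbers for weaker inhibition), compound 2 gives 10.6 nM and stands level with compound 1 within the scatter. Compound 3 `O=C(/C=C/c1cccnc1)NCCCCCCc1cccc(S(=O)(=O)Nc2ccc(F)c(Cl)c2)c1` has one change from compound 2: chloro in place of hydrogen on an aromatic carbon turning 4-fluorophenyl into 3-chloro-4-fluorophenyl. Within the data shown here, the only measured step is a 1.4-fold higher number from compound 1 to compound 2 (0.15 log units; within the scatter) and comes from a different swap on the sulfonamide nitrogen. It offers weak guidance, but no step beyond the scatter is expected in this assay on this basis. Compound 3 is estimated at 9 nM with a range from 3.5 nM to 25 nM in this read-out. The estimated 1.2-fold lower number from compound 2 to compound 3 (0.07 log units; within the scatter) would lie within the scatter.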

Compound 3, half-maximal inhibitory concentration: 150 nM
Compound 3: middle estimate off by 17-fold (1.22 log units), on the low side; the measured number lies above the stated range.
By their numbers in this assay, from the lowest: compounds 1 and 2 (each within the scatter of the next); then compound 3.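

In this assay the ring on the sulfonamide nitrogen proves less forgiving than compounds 1 and 2 suggested: one chloro group, placed ortho to a fluoro group, gives a 14-fold higher number from compound 2 to compound 3 (1.15 log units; beyond the scatter) and so weakens inhibition by a large step. Swapping 2,5-dimethylphenyl for 3-chloro-4-fluorophenyl gives a large step in the same direction (a 20-fold higher number from compound 1 to compound 3 (1.30 log units; beyond the scatter)). A single added atom can therefore matter far more here than the earlier swap did.

From the compounds shown here alone, whether a bromo or methoxy group on that same carbon would cost as much remains open. No available evidence explains the weakening.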